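The compounds below may be only part of what the source reports. "The series", "measured", "known", "first", "only" and "open" are said of these compounds alone.

Compound 1, `C/C(=N\NC(=O)c1ccc(C(F)(F)F)cc1)c1cnccn1`: 1160 nM
Compound 2, `O=C(N/N=C/c1ccccn1)c1ccc(C(F)(F)F)cc1`: 22400 nM
Compound 3, `O=C(NN=C(c1ccccn1)c1ccccn1)c1ccncc1`: 830 nM

These three compounds were tested in an ADME assay on cells (Homo sapiens) for antiproliferative activity, read by MTT assay; a lower number here means a stronger inhibitor, a higher number a weaker inhibitor. Among them compound 1 holds the second highest number. Compound 3 sits closest to it, and the gap between the two lies within the usual scatter of this assay, so no order can be read between them. Compound 2 is furthest away, with a number much higher than that of compound 1, a gap well beyond the scatter.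

Compound 4, `C/C(=N\NC(=O)c1ccccc1)c1cnccn1`, has not yet been measured. It differs from compound 1 in one place: hydrogen in place of trifluoromethyl on an aromatic carbon. The trifluoromethyl leaves and hydrogen enters, on the six-membered aromatic ring of carbon only. For the measured compounds named here, no measured pair shows this same change, so its effect has to be guessed. The step is expected to be a 2.6-fold higher number from compound 1 to compound 4 (0.41 log units; beyond the scatter), toward a higher number and so a weaker inhibitor, of modest size. Compound 4 is therefore expected to give about 3000 nM, within a range from 1000 nM to 10000 nM.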

Compound 4, half-maximal inhibitory concentration: 3620 nM
Compound 4: middle estimate off by 1.2-fold (0.08 log units), on the low side; the range from low to high includes it.
By their numbers in this assay, from the lowest: compounds 3 and 1 (each within the scatter of the next); then compound 4; then compound 2.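

Replacing the trifluoromethyl on the six-membered aromatic ring of carbon only with hydrogen gives, in this assay, a 3.1-fold higher number from compound 1 to compound 4 (0.49 log units; beyond the scatter), a modest step beyond the scatter. For the compounds shown here, this is the first direct sign that the group at this place affects the number, and here trifluoromethyl gives the stronger inhibitor of the two. The step is modest, and compound 4 still gives 3620 nM without the group, so trifluoromethyl is not needed for measurable activity. No measurement shown here explains the step.

This single pair cannot show whether a chlorine, a methoxy group or an amine at the same place would give a lower or higher number. It also leaves open whether the same change would have a similar effect on the core of compound 2.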